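Swapping methoxy for methyl on an anilide-like aryl ring

This account rests on a few compounds, and the source may have more. Where it says the series, first, only, none or still open, it means among the compounds named here.

Three compounds share one core and differ only in the group on a six-membered carbon ring. Compound 1 `COc1ccccc1N1CCn2c1n[nH]c(=O)c2=O` carries a methoxy group; in a functional assay on A549 cells (Homo sapiens) for antiproliferative activity, with a stated time of 72 h, tested at 10 ug/mL (on this read-out higher numbers stand for a stronger effect at the one concentration tested and lower numbers for a weaker effect), compound 1 gives 0%. Compound 2 `COc1ccc(N2CCn3c2n[nH]c(=O)c3=O)cc1` also carries a methoxy group, placed differently, and in this assay compound 2 gives 0%. Compound 3 `Cc1ccc(N2CCn3c2n[nH]c(=O)c3=O)cc1` carries a methyl group instead, and in this assay compound 3 gives 20%. Compound 1 thus sits level with compound 2 at the low end, while compound 3 stands higher.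

Compound 4 `Cc1ccccc1N1CCn2c1n[nH]c(=O)c2=O` has not yet been measured. It differs from compound 1 as follows: methyl in place of methoxy on an aromatic carbon

Going by the values given here, the one measured step that bears on this change is a number 20 percentage points higher from compound 2 to compound 3 (beyond the scatter). Carrying that step over to compound 1, a similar rise is expected, so compound 4 is estimated to reach 20%, between 0% and 40%. That corresponds to an expected step of a number 20 percentage points higher from compound 1 to compound 4 (beyond the scatter).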

Compound 4, a percentage reported as inhibition, at one concentration (the size of the read-out at that concentration, not a potency): 24%
Compound 4: the middle estimate sits 4 percentage points below what was measured; the measured number falls inside the stated range.
By their numbers in this assay, from the lowest: compounds 1 and 2 (each within the scatter of the next); then compounds 3 and 4 (each within the scatter of the next).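

With the group ortho to a large group, methyl in place of methoxy gives a number 24 percentage points higher from compound 1 to compound 4 (beyond the scatter) in this assay. The rise seen earlier on the other pair, where the group is placed differently, therefore appears here as well, so it is not confined to a single placement on the ring. The two steps also agree in size: the same change on two cores in this assay, a number 20 percentage points higher (beyond the scatter) from compound 2 to compound 3 and a number 24 percentage points higher (beyond the scatter) from compound 1 to compound 4, 4 percentage points apart, within the scatter of two such steps

Going by these compounds, these are modest numbers at one concentration, so they show the size of an effect and not a potency, and how much more methyl could add at higher concentrations remains unknown. On these data alone, it also remains open whether a chlorine atom, an amine or a longer chain such as ethyl at this place would go beyond methyl, or whether the ring would do as well with no added group at all.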